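The source may report more compounds than this note shows. Statements on the series, on what has been measured and on what is new or still open speak of the compounds shown alone.

Of the compounds shown here, two that share a core have so far been measured in an ADME assay on microsomes (Rattus norvegicus) for metabolic stability; a higher number here means that the compound lasts longer, a lower number that the compound disappears faster. Compound 1 `O=C(c1cscn1)N1CCC(C(=O)N2N=CC[C@H]2c2ccccc2)CC1` gives 0.65 h in this assay. For the measured compounds named here, compound 2 `O=C(c1ccccc1)N1CCC(C(=O)N2N=CCC2c2ccccc2)CC1` gives 0.0833 h in this assay, the lowest of the two numbers; its only neighbour is compound 1, whose higher value lies well beyond the scatter. Compound 3 `O=C(c1cc[nH]n1)N1CCC(C(=O)N2N=CCC2c2ccccc2)CC1` has not yet been measured. It differs from compound 2 in one place: 1H-pyrazol-3-yl in place of phenyl on a carbonyl carbon. Going by the values given here, compound 1 and compound 2 differ in more than one place, so their two values show only that a different group on that carbonyl went with a longer half-life. On that basis an upward step beyond the scatter is expected, estimated as a 4.2-fold higher number from compound 2 to compound 3 (0.62 log units; beyond the scatter). Compound 3 is therefore estimated at 0.35 h, with a range from 0.1 h to 1 h.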

Compound 3, half-life: 0.317 h
The estimate for compound 3 lay 1.1-fold (0.04 log units) above the measured number; the measured number falls inside the stated range.
By their numbers in this assay, from the lowest: compound 2; then compound 3; then compound 1.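

In this assay, putting 1H-pyrazol-3-yl in place of phenyl on a carbonyl carbon gives a 3.8-fold higher number from compound 2 to compound 3 (0.58 log units; beyond the scatter). For the compounds shown here, this is the first change at this position with the rest of the structure held fixed, so the longer half-life can now be tied to this one replacement rather than to a mixture of differences. The data do not show which feature of the entering ring, a five-membered aromatic ring with 2 hetero atoms and 1 hydrogen-bond donor, accounts for the step, and no measurement bears on its cause.

The compounds shown leave open whether a 1-methylpyrazolyl group, with methyl replacing the ring hydrogen on nitrogen, or a pyridyl ring would give a similar half-life. Also open, from the compounds shown here alone, is how a single defined stereoisomer of compound 3 would behave.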